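The compounds below may be only part of what the source reports. "The series", "measured", "known", "first", "only" and "open" are said of these compounds alone.

Working notes on the series. In a functional assay on CHO cells for antagonist activity at Orexin/Hypocretin receptor type 1 (Homo sapiens), read by FLIPR and calcium flux (a lower number here means a stronger inhibitor, a higher number a weaker inhibitor), compound 1 `Cc1cccc(NC(=O)CSc2nnc(-c3ccoc3C)n2Cc2ccco2)c1` gives 2510 nM. Compound 2 `Cc1occc1-c1nnc(SCC(=O)Nc2ccc(F)cc2)n1Cc1ccco1` gives only > 15800 nM, which is a limit of the assay and not a number. Compound 2 sits at the limit of > 15800 nM in this assay, at which 1 of the 2 values shown sits. Going by the values given here, the single measured step, an at least 6.2-fold higher number from compound 1 to compound 2 (0.79 log units; beyond the scatter), moved the aryl substituent on the amide-type nitrogen and weakened inhibition. Compound 3 `Cc1occc1-c1nnc(SCC(=O)Nc2cccc(F)c2)n1Cc1ccco1` now differs from compound 2 by 3-fluorophenyl in place of 4-fluorophenyl on an amide-type nitrogen. Compound 1 gives 2510 nM with a substituent in the same ring position. On that basis, compound 3 is expected to come in stronger than compound 2, an estimated at least 2.6-fold lower number from compound 2 to compound 3 (0.42 log units; beyond the scatter). Compound 3 is therefore estimated at 6000 nM, between 2000 nM and 20000 nM.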

Compound 3, inhibition constant: > 15800 nM
Compound 3: a limit, no number (the forecaster's own chance of this, stated with the estimate: 40%); middle value at least 2.6-fold (0.42 log units) away from the limit.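

Placing the fluoro as 3-fluorophenyl rather than 4-fluorophenyl on the amide-type nitrogen gives no measurable inhibition in this assay: compound 3 gives > 15800 nM, a limit of the assay and not a number. Fluoro in place of methyl on an aromatic carbon gives an at least 6.2-fold higher number from compound 1 to compound 3 (0.79 log units; beyond the scatter), so the ring position alone does not preserve the value of compound 1. The step from compound 2 to compound 3 cannot be read, since both values are limits: the limit of > 15800 nM in this assay, at which 2 of the 3 values shown sit.

On these data alone, whether 3-fluorophenyl and 4-fluorophenyl differ at all remains open. Also open, as far as these compounds go, is whether chloro or methoxy on that aromatic carbon would behave like methyl or like fluoro.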